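This account rests on a few compounds, and the source may have more. Where it says the series, first, only, none or still open, it means among the compounds named here.

Measured so far:
compound 1 `Nc1ncnn2c([C@@H]3O[C@H](CO)[C@@H](O)[C@H]3O)cc(C#CC3CC3)c12` — 20 nM
compound 2 `Nc1ncnn2c([C@@H]3O[C@H](CO)[C@@H](O)[C@H]3O)cc(C#Cc3cccs3)c12` — 32000 nM
compound 3 `Nc1ncnn2c([C@@H]3O[C@H](CO)[C@@H](O)[C@H]3O)cc(-c3ccc(Cl)cc3)c12` — 56700 nM

In a functional assay on CAPAN-1 cells (Homo sapiens) for antiproliferative activity, with a stated time of 72 h (a higher number here means a weaker inhibitor, a lower number a stronger inhibitor), compound 2 gives the second highest of the three numbers. Its nearest neighbour is compound 3, a 1.8-fold higher number from compound 2 to compound 3 (0.25 log units; within the scatter); its furthest is compound 1, a 1600-fold higher number from compound 1 to compound 2 (3.20 log units; beyond the scatter). Compound 4 `Nc1ncnn2c([C@@H]3O[C@H](CO)[C@@H](O)[C@H]3O)cc(-c3ccccc3F)c12` differs from compound 2 in one place: 2-fluorophenyl in place of 2-(thiophen-2-yl)ethynyl on an aromatic carbon. The step that bears most directly on this change is the one in which a flat ring replaced a ring on a triple bond, a 1.8-fold higher number from compound 2 to compound 3 (0.25 log units; within the scatter), which stayed within the scatter. The large steps of a 1600-fold higher number from compound 1 to compound 2 (3.20 log units; beyond the scatter) and a 2800-fold higher number from compound 1 to compound 3 (3.45 log units; beyond the scatter) concern the cyclopropyl group, which compound 2 already lacks. A step from compound 2 to compound 4 within the scatter is therefore expected, a 1.4-fold higher number from compound 2 to compound 4 (0.15 log units; within the scatter). Compound 4 is estimated at 45000 nM, between 15000 nM and 140000 nM.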

Compound 4, half-maximal inhibitory concentration: > 100000 nM
Compound 4 was reported as a limit; the forecaster's own chance of this, stated with the estimate: 25%; middle value at least 2.2-fold (0.34 log units) from the limit.
By their numbers in this assay, from the lowest: compound 1; then compounds 2 and 3 (each within the scatter of the next). At a limit, above all of these: compound 4.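

In this assay compound 4 is reported only as a limit, not as a number: the limit of > 100000 nM in this assay, at which 1 of the 4 values shown sits. Putting 2-fluorophenyl in place of 2-(thiophen-2-yl)ethynyl gives an at least 3.1-fold higher number from compound 2 to compound 4 (0.49 log units; beyond the scatter), so this position can still register a change once the cyclopropyl group is gone. Exchanging the two substituted phenyl groups gives an at least 1.7-fold higher number from compound 3 to compound 4 (0.24 log units; that floor lies within the scatter), which does not separate them, while an at least 5000-fold higher number from compound 1 to compound 4 (3.69 log units; beyond the scatter) leaves 2-cyclopropylethynyl far ahead. From the compounds shown here alone, whether a propyl chain or a cyclobutyl ring on the triple bond would match cyclopropyl stays open. So does the effect of an amine on the phenyl ring.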